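The source may hold more compounds than are shown below. What is called first, only, known or untested is meant among the compounds shown, and "the series" means these compounds.

Measured compounds in a functional assay on HT-29 cells (Homo sapiens) for antiproliferative activity, read by sulforhodamine B assay, with a stated time of 48 h; a higher number here means a weaker inhibitor, a lower number a stronger inhibitor:
compound 1, `CC(C)c1ccccc1OS(=O)(=O)c1ccc(NC(=O)CCl)cc1`, 5600 nM
compound 2, `CCNC(=O)Nc1ccc(S(=O)(=O)Oc2ccccc2C(C)C)cc1`, 1100 nM
compound 3, `CCCNC(=O)Nc1ccc(S(=O)(=O)Oc2ccccc2C(C)C)cc1`, 6300 nM

Compound 3 stands at the upper end of these three numbers. Its gap to compound 1 is within the scatter (a 1.1-fold higher number from compound 1 to compound 3 (0.05 log units; within the scatter)), while compound 2 is clearly set apart: a 5.1-fold lower number from compound 1 to compound 2 (0.71 log units; beyond the scatter) and a 5.7-fold higher number from compound 2 to compound 3 (0.76 log units; beyond the scatter) are both beyond the scatter.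

Compound 4, `CC(C)c1ccccc1OS(=O)(=O)c1ccc(NC(=O)NCC2CCCC2)cc1`, differs from compound 3 in one place: cyclopentyl in place of ethyl on a saturated chain carbon bound to an amide-type nitrogen. Among the measured compounds shown here, none of the measured steps changes this chain carbon in the same way. The step that comes closest is the lengthening of the chain by a methyl, a 5.7-fold higher number from compound 2 to compound 3 (0.76 log units; beyond the scatter), which moved the number in this assay upward by a modest amount; the other two steps, a 5.1-fold lower number from compound 1 to compound 2 (0.71 log units; beyond the scatter) and a 1.1-fold higher number from compound 1 to compound 3 (0.05 log units; within the scatter), concern the carbonyl substituent and do not touch the chain. For the measured compounds named here, with only one chain-lengthening step to go on, and that step pointing toward a weaker inhibitor, no step beyond the scatter is expected from compound 3 to compound 4, but the uncertainty is wide.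

Compound 4 is therefore estimated at 7000 nM, with a range from 1500 nM to 30000 nM, which corresponds to an expected step of a 1.1-fold higher number from compound 3 to compound 4 (0.05 log units; within the scatter).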

Compound 4, half-maximal inhibitory concentration: 6800 nM
Beside the measured number, compound 4's estimate is 1.0-fold (0.01 log units) above it, within the range that was stated.
By their numbers in this assay, from the lowest: compound 2; then compounds 1, 3 and 4 (each within the scatter of the next).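

In this assay, putting cyclopentyl in place of ethyl on the saturated chain carbon bound to an amide-type nitrogen brings in one five-membered non-aromatic ring of carbon only and raises the group from 2 heavy atoms to 5, yet the reading does not separate compound 4 from the propylamino compound (a 1.1-fold higher number from compound 3 to compound 4 (0.03 log units; within the scatter)). The ethylamino compound stays apart from this ring-bearing compound (a 6.2-fold higher number from compound 2 to compound 4 (0.79 log units; beyond the scatter)), while the chloromethyl compound does not (a 1.2-fold higher number from compound 1 to compound 4 (0.08 log units; within the scatter)), so among the compounds sharing this position, compound 2 remains the only one set apart. Nothing measured here explains why the cyclopentyl group and the propyl group read alike.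

Going by these compounds, whether a butyl chain or an open pentyl chain would read with compound 3 and compound 4 or with compound 2 remains open, and so does whether the ring itself contributes anything at this position. Also open is how a hydroxyl group or an amine at the end of the chain would read in this assay, since every chain shown carries carbon only.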